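Replacing 4-methoxyphenyl on an amide-type nitrogen

The source may hold more compounds than are shown below. What is called first, only, known or untested is meant among the compounds shown, and "the series" means these compounds.

Measured in a functional assay on HOS cells (Homo sapiens) for inhibition, read by MTT assay, with a stated time of 72 h; on this read-out higher numbers stand for weaker inhibition and lower numbers for stronger inhibition:
- compound 1 `O=C(CCC(=O)OCCCCCCSc1ccc([N+](=O)[O-])c2nonc12)Nc1cccc(Cl)c1`: 1920 nM
- compound 2 `O=C(CCC(=O)OCCCCCCSc1ccc([N+](=O)[O-])c2nonc12)Nc1ccc(Br)cc1`: 2160 nM
- compound 3 `COc1ccc(NC(=O)CCC(=O)OCCCCCCSc2ccc([N+](=O)[O-])c3nonc23)cc1`: 1800 nM

The three compounds share one core and differ only in the phenyl group on the amide-type nitrogen. Compound 3, at 1800 nM, stands level with the other two, since none of the steps among them exceeds the scatter. The change of group gave a 1.1-fold lower number from compound 1 to compound 3 (0.03 log units; within the scatter) and a 1.1-fold higher number from compound 1 to compound 2 (0.05 log units; within the scatter), and the exchange of bromo for methoxy gave a 1.2-fold lower number from compound 2 to compound 3 (0.08 log units; within the scatter).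

Compound 4 `CN(C)CCNC(=O)CCC(=O)OCCCCCCSc1ccc([N+](=O)[O-])c2nonc12` is still unmeasured in this assay. It carries 2-(dimethylamino)ethyl in place of 4-methoxyphenyl on an amide-type nitrogen. This change goes further than any measured step, as all three measured compounds keep a phenyl group at that place. Those small steps, such as a 1.1-fold lower number from compound 1 to compound 3 (0.03 log units; within the scatter), therefore give only limited guidance. They show no sensitivity to the substituted phenyl groups tried, but they say nothing about removing the ring.

As far as these compounds go, no shift beyond the scatter is expected, and the direction remains open, so the expected change is a 1.4-fold higher number from compound 3 to compound 4 (0.14 log units; within the scatter). For compound 4 the estimated value is 2500 nM, with an expected range from 800 nM to 8000 nM.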

Compound 4, half-maximal inhibitory concentration: 5020 nM
For compound 4 the middle estimate is 2.0-fold (0.30 log units) below the measured one; the measured number falls inside the stated range.
By their numbers in this assay, from the lowest: compounds 3, 1 and 2 (each within the scatter of the next); then compound 4.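

In this assay, this position proves not to be indifferent to every group: the substituted phenyl groups had stayed level with one another, but 2-(dimethylamino)ethyl moves the number up against each of them (a 2.8-fold higher number from compound 3 to compound 4 (0.45 log units; beyond the scatter); a 2.3-fold higher number from compound 2 to compound 4 (0.37 log units; beyond the scatter); a 2.6-fold higher number from compound 1 to compound 4 (0.42 log units; beyond the scatter)). All three steps lie beyond the scatter and run the same way, so compound 4 has the highest number of the four, although each step is only modest. The change takes out a six-membered aromatic ring of carbon only and brings in a chain with no ring that carries a dimethylamino group, yet no measurement shown here accounts for the shift.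

Because the ring leaves and the amine enters in a single exchange, the compounds shown cannot separate the two changes: a plain alkyl chain such as butyl on the amide-type nitrogen, or a benzyl group, would help to tell them apart. As far as these compounds go, it also remains open how a carboxylic acid at the end of the chain, a longer chain ending in the same dimethylamino group, or a cyclic amine such as morpholine would read here.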